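A few compounds are considered here, and "the series" means these few. Any claim that something is new, unique, unknown or untested is made for them only; others in the source may bear on it.

Among the measured compounds shown here, in a functional assay on HepG2 cells (Homo sapiens) for antiproliferative activity, read by MTT assay, with a stated time of 72 h (on this read-out lower numbers stand for stronger inhibition and higher numbers for weaker inhibition), compound 1 `Cc1cc(C)cc(OCCCON2C(N)=NC(N)=NC23CCOCC3)c1` gives 680 nM and compound 2 `NC1=NC2(CCOCC2)N(OCCCOc2cccc(Br)c2)C(N)=N1` gives 320 nM, the lowest of the two numbers so far. Compound 3 `NC1=NC2(CCOCC2)N(OCCCOc2cccc(Cl)c2)C(N)=N1` differs from compound 2 by one exchange, (chloro in place of bromo on an aromatic carbon), chloro in place of bromo on an aromatic carbon. For the measured compounds named here, only one measured step bears on it, a 2.1-fold lower number from compound 1 to compound 2 (0.33 log units; beyond the scatter), where 3-bromophenyl replaced 3,5-dimethylphenyl. Going by the values given here, that step was modest, and no measured step covers this exchange itself, so no change beyond the scatter is expected in this assay. The expected step is a 1.2-fold higher number from compound 2 to compound 3 (0.07 log units; within the scatter). Compound 3 is estimated at 380 nM, with an expected range of 170 nM to 800 nM.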

Compound 3, half-maximal inhibitory concentration: 150 nM
For compound 3 the middle estimate is 2.5-fold (0.40 log units) above the measured one; the measured number lies below the stated range.
By their numbers in this assay, from the lowest: compound 3; then compound 2; then compound 1.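

In this assay, the halogen on this aromatic carbon matters: chloro in place of bromo gives a 2.1-fold lower number from compound 2 to compound 3 (0.33 log units; beyond the scatter), a step of the same printed size as the earlier exchange of the whole aryl group. Against the 3,5-dimethylphenyl of the first compound, 3-chlorophenyl gives a 4.5-fold lower number from compound 1 to compound 3 (0.66 log units; beyond the scatter), and compound 3 now holds the lowest of the three numbers. No evidence at hand accounts for this difference between the two halogens. Open, as far as these compounds go, is how fluoro, methoxy or an amine would read at this place, and what a longer chain joining the aryl ether to the shared core would do.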